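A few compounds are considered here, and "the series" means these few. Any claim that something is new, unique, unknown or untested is made for them only; others in the source may bear on it.

The measured compounds, in a functional assay on the whole organism for inhibition, with Rattus norvegicus as the target; a higher number here means that more compound is needed for the effect, a lower number that less compound is needed:
compound 1 `CC1CC/C(=N\Nc2ccccc2O)c2ncc(C(=O)O)c(=O)n21` gives 0.26 umol/kg
compound 2 `Cc1cccc(N/N=C2\CCC(C)n3c2ncc(C(=O)O)c3=O)c1` gives 0.4 umol/kg
compound 3 `Cc1ccc(N/N=C2\CCC(C)n3c2ncc(C(=O)O)c3=O)cc1` gives 1.3 umol/kg

Compound 3 carries the highest number of the three: a 3.3-fold higher number from compound 2 to compound 3 (0.51 log units; beyond the scatter) and a 5.0-fold higher number from compound 1 to compound 3 (0.70 log units; beyond the scatter), both beyond the scatter. Compound 4 `CCCCc1ccc(N/N=C2\CCC(C)n3c2ncc(C(=O)O)c3=O)cc1` differs from compound 3 by propyl in place of hydrogen on a saturated chain carbon bound to an aromatic carbon. Among the measured compounds shown here, no measured step touches a change of this kind; the three steps known (a 1.5-fold higher number from compound 1 to compound 2 (0.19 log units; within the scatter), a 5.0-fold higher number from compound 1 to compound 3 (0.70 log units; beyond the scatter), a 3.3-fold higher number from compound 2 to compound 3 (0.51 log units; beyond the scatter)) each exchange one substituted phenyl for another on the amine nitrogen and say nothing about lengthening a chain. With nothing to lean on, a step within the scatter or a modest one in either direction is expected in this assay. Compound 4 is therefore estimated at 1.6 umol/kg, in the range 0.5 umol/kg to 5 umol/kg, which means an expected 1.2-fold higher number from compound 3 to compound 4 (0.09 log units; within the scatter).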

Compound 4, dose for 50% inhibition: 7.8 umol/kg
The estimate for compound 4 lay 4.9-fold (0.69 log units) below the measured number; measured number above the stated range.
By their numbers in this assay, from the lowest: compounds 1 and 2 (each within the scatter of the next); then compound 3; then compound 4.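

In this assay, among the compounds shown here, the change from methyl to butyl gives a 6.0-fold higher number from compound 3 to compound 4 (0.78 log units; beyond the scatter), the first look at chain length on this phenyl group, since the earlier steps only exchanged one substituted phenyl for another. Lengthening this chain therefore takes the number beyond the scatter, towards more compound being needed. No measurement shown accounts for this.

On these data alone, whether an ethyl or propyl chain would already give part of this step remains open. So does whether a longer chain, or an amine or carboxylic acid at the chain end, would follow it.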